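Propyl to butyl amide on two cores

The compounds below may be only part of what the source reports. "The series", "measured", "known", "first", "only" and "open" are said of these compounds alone.

Compound 1 `CCCNC(=O)c1ccc2c(ccn2-c2ncc3c(n2)N(c2ccn(C)n2)C(CC)C(=O)N3C)c1` and compound 3 `CCCCNC(=O)c1ccc2c(ccn2-c2ncc3c(n2)N(c2ccn(C)n2)C(CC)C(=O)N3C)c1` share one core; compound 2 `CCCNC(=O)c1ccc2c(ccn2-c2ncc3c(n2)N(C2CCCC2)[C@H](CC)C(=O)N3C)c1` and the unmeasured compound 4 `CCCCNC(=O)c1ccc2c(ccn2-c2ncc3c(n2)N(C2CCCC2)[C@H](CC)C(=O)N3C)c1` share another. The difference between the two cores is not broken down here. In a functional assay on NCI-H1975 cells (Homo sapiens) for antiproliferative activity, read by CCK-8 assay, with a stated time of 72 h (on this read-out higher numbers stand for weaker inhibition of growth and lower numbers for stronger inhibition of growth), compound 1 gives 11000 nM and compound 3 gives 12000 nM. The change between them, (methyl in place of hydrogen on a saturated chain carbon, three bonds along the chain from an amide-type nitrogen), made a 1.1-fold higher number from compound 1 to compound 3 (0.04 log units; within the scatter). In this assay compound 2 gives 786 nM, the lowest of the three measured numbers, and its steps to both compound 1 and compound 3 lie beyond the scatter. Compound 4 carries the same change on the core of compound 2: methyl in place of hydrogen on a saturated chain carbon, three bonds along the chain from an amide-type nitrogen. The place of the change is the same word for word on both cores. For the measured compounds named here, the single measured instance of this change left the number essentially where it stood, so the expected step in this assay is a 1.1-fold higher number from compound 2 to compound 4 (0.03 log units; within the scatter), resting on a 1.1-fold higher number from compound 1 to compound 3 (0.04 log units; within the scatter). Compound 4 is therefore estimated at 850 nM, between 400 nM and 1800 nM, in this assay. Going by the values given here, only one prior instance backs this, so the range is kept wide.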

Compound 4, concentration for 50% growth inhibition: 990 nM
Estimate against measurement, compound 4: 1.2-fold (0.07 log units) below, within the range that was stated.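

In this assay the propyl to butyl change on the core of compound 2 gives a 1.3-fold higher number from compound 2 to compound 4 (0.10 log units; within the scatter), so on this second core too the step stays within the scatter. The two instances of the change agree, and within this pair of cores the step carries over from one core to the other: the same change on two cores in this assay, a 1.1-fold higher number (0.04 log units; within the scatter) from compound 1 to compound 3 and a 1.3-fold higher number (0.10 log units; within the scatter) from compound 2 to compound 4, 1.2-fold (0.06 log units) apart, within the scatter of two such steps This shows agreement only for a change whose step is within the scatter on both cores, in one assay and across two pairs; it does not show that a change with a step beyond the scatter would carry over in the same way, nor does it break down the difference between the two cores.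

Open on either core is what a longer chain on the amide, a branched chain, or a chain ending in an amine or a carboxylic acid would do to the number. Also open, on these data alone, is which part of the difference between the two cores goes with the gap between their numbers.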